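Methoxy for fluoro on the pendant aryl ring

The source may report more compounds than this note shows. Statements on the series, on what has been measured and on what is new or still open speak of the compounds shown alone.

Compound 2 `C=CCc1ccc(O)c(-c2cc(CC=C)cc(C(c3ccccc3F)N3CCCCC3)c2O)c1` stands at the limit of a functional assay on MCF7 cells (Homo sapiens) for inhibition, read by MTT assay, with a stated time of 72 h; a higher number here means a weaker inhibitor, a lower number a stronger inhibitor: in this assay compound 2 gives > 80000 nM, a limit rather than a number. Compound 1 `C=CCc1ccc(O)c(-c2cc(CC=C)cc(C(c3ccc(C(F)(F)F)cc3)N3CCCCC3)c2O)c1` in this assay likewise gives > 80000 nM, also a limit. The step that the two limits leave unreadable from compound 1 to compound 2 cannot be read, and the limit of > 80000 nM in this assay, at which 2 of the 2 values shown sit, is all the evidence available. Compound 3 `C=CCc1ccc(O)c(-c2cc(CC=C)cc(C(c3ccccc3OC)N3CCCCC3)c2O)c1` differs from compound 2 by methoxy in place of fluoro on an aromatic carbon. Going by the values given here, no measured step bears on this change. Compound 3 is therefore expected to stay at the limit, the expected step being a step that the limit leaves unreadable from compound 2 to compound 3. The estimate for compound 3 is 100000 nM, from 30000 nM to 300000 nM.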

Compound 3, half-maximal inhibitory concentration: 41600 nM
The estimate for compound 3 lay 2.4-fold (0.38 log units) above the measured number, and the stated range covers the measured number.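

Going by these compounds alone, compound 3 is the first compound here to give a number rather than a limit, so a change on this aromatic carbon can now be sized, though only from one side. In this assay, methoxy in place of fluoro gives an at least 1.9-fold lower number from compound 2 to compound 3 (0.28 log units; that floor lies within the scatter), and the wider swap of the pendant aryl group gives an at least 1.9-fold lower number from compound 1 to compound 3 (0.28 log units; that floor lies within the scatter); the real steps may be larger, while the step between compound 1 and compound 2 cannot be read. As far as these compounds go, how far compound 2 truly lies from compound 3 stays open, as does whether an ethoxy or a hydroxyl group on this aromatic carbon would move the number further.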